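This account rests on a few compounds, and the source may have more. Where it says the series, first, only, none or still open, it means among the compounds named here.

In a functional assay on MCF7 cells (Homo sapiens) for antiproliferative activity, read by CellTiter-Glo, with a stated time of 5 days (on this read-out lower numbers stand for stronger inhibition and higher numbers for weaker inhibition), compound 1 `O=C(O)/C=C/c1ccc(/C(=C(\c2ccc(F)cc2Cl)C2CCC2)c2ccc3nccn3c2)cc1` gives 4.4 nM, compound 2 `O=C(O)/C=C/c1ccc(/C(=C(\c2ccc(F)cc2Cl)C2CCC2)c2ccc(-c3cncs3)cc2)cc1` gives 4.2 nM and compound 3 `O=C(O)/C=C/c1ccc(/C(=C(\c2ncc(C(F)(F)F)cc2Cl)C2CCC2)c2ccc(-c3cncs3)cc2)cc1` gives 7.3 nM, so compound 2 stands within the scatter of both others. Compound 4 `O=C(O)/C=C/c1ccc(/C(=C(\c2ccc(F)cc2Cl)C2CCC2)c2ccc(-c3cn[nH]c3)cc2)cc1` differs from it by 1H-pyrazol-4-yl in place of 1,3-thiazol-5-yl on an aromatic carbon. Going by the values given here, two measured steps bear on this change, and both stayed within the scatter. The step of a 1.0-fold lower number from compound 1 to compound 2 (0.02 log units; within the scatter) brought in the whole group holding the 1,3-thiazol-5-yl ring, while a 1.7-fold higher number from compound 2 to compound 3 (0.24 log units; within the scatter) left that ring untouched. Neither exchanges this ring alone, so no shift beyond the scatter is expected in this assay. The expected step is a 1.2-fold higher number from compound 2 to compound 4 (0.08 log units; within the scatter). The estimate for compound 4 is 5 nM, within an expected range of 2 nM to 13 nM.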

Compound 4, half-maximal inhibitory concentration: 2.9 nM
Compound 4: middle estimate off by 1.7-fold (0.24 log units), on the high side; measured number inside the range.
By their numbers in this assay, from the lowest: compounds 4, 2, 1 and 3 (each within the scatter of the next, the first and the last beyond it).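

In this assay, going by these compounds alone, a 1.4-fold lower number from compound 2 to compound 4 (0.16 log units; within the scatter) is the first step to exchange the ring alone: on an aromatic carbon para to a large group, 1H-pyrazol-4-yl, which brings a hydrogen-bond donor, replaces 1,3-thiazol-5-yl without leaving the scatter. The step of a 1.5-fold lower number from compound 1 to compound 4 (0.18 log units; within the scatter) also stays within it, so this read-out does not separate the two groups exchanged there. Nothing available explains either step. From the compounds shown here alone, whether an amine or a longer chain in place of the five-membered ring would shift the number beyond the scatter remains open.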